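A Methoxy Added Across Two Related Cores

A few compounds are considered here, and "the series" means these few. Any claim that something is new, unique, unknown or untested is made for them only; others in the source may bear on it.

Compound 1 `COc1ccc(/C=C/C2CC(=O)C=CO2)cc1OC` and compound 2 `COc1cc(/C=C/C2CC(=O)C=CO2)cc(OC)c1OC` share one core, while compound 3 `COc1ccc(/C=C/c2cc(=O)cco2)cc1` and the still unmeasured compound 4 `COc1ccc(/C=C/c2cc(=O)cco2)cc1OC` share another; the difference between the two cores is not broken down here. In a functional assay on OVCAR-3 cells (Homo sapiens) for inhibition, read by sulforhodamine B assay, with a stated time of 48 h (on this read-out higher numbers stand for weaker inhibition of growth and lower numbers for stronger inhibition of growth), compound 1 gives 74.3 uM, compound 2 gives 85.4 uM and compound 3 gives 328 uM. Compound 3 thus carries the highest number of the three, with compound 2 nearest to it and compound 1 furthest, both separated from it by steps beyond the scatter. The change from compound 1 to compound 2, (methoxy in place of hydrogen on an aromatic carbon), produced a 1.1-fold higher number from compound 1 to compound 2 (0.06 log units; within the scatter). The change from compound 3 to compound 4 is methoxy in place of hydrogen on an aromatic carbon; it is the same kind of change, though around the place in compound 1 the carbon is also meta to a methoxy group, which is not so in compound 3. Because a 1.1-fold higher number from compound 1 to compound 2 (0.06 log units; within the scatter) stayed within the scatter, the step expected is a 1.0-fold higher number from compound 3 to compound 4 (0.02 log units; within the scatter). Compound 4 is therefore estimated at 340 uM in this assay, within an expected range from 160 uM to 720 uM.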

Compound 4, concentration for growth inhibition (reported as GI): 540 uM
Compound 4: the middle estimate sits 1.6-fold (0.20 log units) below what was measured; low and high end bracket the measured number.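

In this assay methoxy in place of hydrogen on an aromatic carbon gives a 1.6-fold higher number from compound 3 to compound 4 (0.22 log units; within the scatter) on the second core, and set beside the step on the first core the two do not differ: the same change on two cores in this assay, a 1.1-fold higher number (0.06 log units; within the scatter) from compound 1 to compound 2 and a 1.6-fold higher number (0.22 log units; within the scatter) from compound 3 to compound 4, 1.4-fold (0.16 log units) apart, within the scatter of two such steps. Within these two pairs, then, the change carries from one core to the other as a step that stays within the scatter on each. Going by these compounds alone, this does not show that the step would stay as small across the wider series: only two pairs stand behind it, in a single assay, and the new methoxy of compound 4 sits ortho to a methoxy group, so the comparison says nothing about a methoxy placed elsewhere on the ring or about what separates the two cores.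

The compounds shown leave open whether a hydroxy group, a fluorine or an amine on the same aromatic carbon would move the number beyond the scatter. They also leave open whether a longer chain such as ethoxy would behave alike on both cores, and whether the agreement holds in any read-out other than this assay.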